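The source may hold more compounds than are shown below. What is called first, only, known or untested is meant among the compounds shown, and "the series" means these compounds.

Compound 1 `CC(=O)OC[C@H]1O[C@H](OC2=CC(=O)c3ccccc3C2=O)[C@H](OC(C)=O)[C@@H](OC(C)=O)[C@@H]1OC(C)=O` and compound 2 `CC(=O)N[C@H]1[C@@H](OC2=CC(=O)c3ccccc3C2=O)O[C@H](COC(C)=O)[C@@H](OC(C)=O)[C@@H]1OC(C)=O` share one core and differ in a single place: acetamido in place of acetoxy on a saturated ring carbon. In a functional assay on MDA-MB-231 cells (Homo sapiens) for cytotoxicity, read by sulforhodamine B assay, with a stated time of 72 h (on this read-out lower numbers stand for stronger inhibition and higher numbers for weaker inhibition), compound 1 gives 8290 nM, while compound 2 gives 19800 nM, so this change produced a 2.4-fold higher number from compound 1 to compound 2 (0.38 log units; beyond the scatter). Compound 3 `CC(=O)OC[C@H]1O[C@@H](n2cc(COC3=CC(=O)c4ccccc4C3=O)nn2)[C@H](OC(C)=O)[C@@H](OC(C)=O)[C@@H]1OC(C)=O` has a different core; how its core differs from that of compound 1 is not broken down here. In this assay compound 3 gives 14000 nM, a number within the usual scatter of both compound 1 and compound 2. Compound 4 `CC(=O)N[C@@H]1[C@@H](OC(C)=O)[C@H](OC(C)=O)[C@@H](COC(C)=O)O[C@H]1n1cc(COC2=CC(=O)c3ccccc3C2=O)nn1` has not been measured; it differs from compound 3 by the same change, at the same place: acetamido in place of acetoxy on a saturated ring carbon. Because the same change earlier gave a 2.4-fold higher number from compound 1 to compound 2 (0.38 log units; beyond the scatter), a step of similar size is expected here, a 2.2-fold higher number from compound 3 to compound 4 (0.35 log units; beyond the scatter). Compound 4 is therefore estimated at 31000 nM, with a plausible range from 15000 nM to 65000 nM.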

Compound 4, half-maximal inhibitory concentration: > 50000 nM
Compound 4 gave a limit, no number; the forecaster's own chance of this, stated with the estimate: 10%; middle value at least 1.6-fold (0.20 log units) from the limit.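

In this assay, compound 4 gives > 50000 nM, which is a limit of the assay and not a number. Putting acetamido in place of acetoxy gives a higher number on both cores, with the new step being an at least 3.5-fold higher number from compound 3 to compound 4 (0.55 log units; beyond the scatter), so the direction of the change carries over from one core to the other: the same change on two cores in this assay, a 2.4-fold higher number (0.38 log units; beyond the scatter) from compound 1 to compound 2 and an at least 3.5-fold higher number (0.55 log units; beyond the scatter) from compound 3 to compound 4; the limit leaves it open whether they differ. Whether its size carries over as well is not shown, as compound 4 has no exact value.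

The compounds shown leave open how a free amine or a longer acyl chain on the same saturated ring carbon would behave. Also open, as far as these compounds go, is whether the step would hold on a third core.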